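A few compounds are considered here, and "the series" means these few. Any claim that something is new, unique, unknown or untested is made for them only; others in the source may bear on it.

In an assay on isolated protein for inhibition of Amine oxidase [flavin-containing] B (Homo sapiens), read by fluorescence and spectrophotometry, with a stated time of 20 min (on this read-out lower numbers stand for stronger inhibition and higher numbers for weaker inhibition), three compounds have been measured so far. Compound 2 `O=C1CCc2cc(OCc3cccc(Br)c3)ccc2N1` gives 86 nM, the lowest of the three numbers. Compound 1 `O=C1CCc2cc(OCc3cccc(Cl)c3)ccc2N1` carries a chloro where compound 2 carries a bromo; compound 1 gives 620 nM. Compound 3 `O=C1CCc2cc(OCCCc3ccccc3)ccc2N1`, with a longer chain and no halogen, gives 284 nM. Among the measured compounds shown here, the only step between measured compounds that differ in a single place is a 7.2-fold lower number from compound 1 to compound 2 (0.86 log units; beyond the scatter). Compound 4 `O=C1CCc2cc(OCc3ccccc3)ccc2N1` has not yet been measured. It differs from compound 2 by hydrogen in place of bromo on an aromatic carbon, on an aromatic carbon of a six-membered aromatic ring of carbon only, meta to a large group. The step from compound 1 to compound 2 bears on this change: it exchanged one halogen for another at the same place and was beyond the scatter. Removing the halogen altogether is therefore expected to move the number upward, toward weaker inhibition, by a step of comparable size, which would be a 9.3-fold higher number from compound 2 to compound 4 (0.97 log units; beyond the scatter). Compound 4 is thus expected to give about 800 nM, within a range from 250 nM to 2500 nM.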

Compound 4, half-maximal inhibitory concentration: 4010 nM
Compound 4: the middle estimate sits 5.0-fold (0.70 log units) below what was measured, outside the stated range (above it).
By their numbers in this assay, from the lowest: compound 2; then compound 3; then compound 1; then compound 4.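

In this assay, the group at this place on the aromatic ring carries much of the inhibition: hydrogen in place of bromo gives a 47-fold higher number from compound 2 to compound 4 (1.67 log units; beyond the scatter), the largest step among these compounds. Hydrogen in place of chloro gives a 6.5-fold higher number from compound 1 to compound 4 (0.81 log units; beyond the scatter), so chloro also gives a lower number than hydrogen, not only a higher one than bromo. Together with a 7.2-fold lower number from compound 1 to compound 2 (0.86 log units; beyond the scatter), this gives an order across three compounds that differ only here: bromo in compound 2 has the lowest number, then chloro in compound 1, then hydrogen in compound 4.

Nothing given here shows why these groups differ so much. Also open, as far as these compounds go, is whether iodo, methyl or methoxy at this place would extend this order or break it.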